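A few compounds are considered here, and "the series" means these few. Any claim that something is new, unique, unknown or untested is made for them only; others in the source may bear on it.

Measured so far in an ADME assay on the whole organism for pharmacokinetics, with Rattus norvegicus as the target, at a dose of 5 mg/kg by the oral route (a lower number here means less compound in the circulation, a higher number more compound in the circulation at the dose given), are two compounds:

- compound 1 `Cc1nc(-c2nc[nH]n2)ccc1-c1cnc2c(n1)N(C(C)C)C(=O)CN2` with 2080 nM
- compound 2 `COCCN1C(=O)CNc2ncc(-c3ccc(-c4nc[nH]n4)nc3C)nc21` with 1960 nM

These two values lie within the scatter of each other, so compound 2 stands level with compound 1, and neither can be ranked above the other. The next compound is compound 3 `CO[C@H]1CC[C@H](N2C(=O)CNc3ncc(-c4ccc(-c5nc[nH]n5)nc4C)nc32)CC1`, which carries 4-methoxycyclohexyl in place of 2-methoxyethyl on an amide-type nitrogen in a ring. The counted difference is 4-methoxycyclohexyl in place of 2-methoxyethyl on an amide-type nitrogen in a ring and it adds a six-membered non-aromatic ring of carbon only.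

Going by the values given here, one measured step bears on this change. It sits at the same nitrogen, where 2-methoxyethyl replaces isopropyl, and it amounts to a 1.1-fold lower number from compound 1 to compound 2 (0.03 log units; within the scatter) in this series. That step stayed within the scatter, but neither of its groups holds a ring, so it guides the new change only loosely. No step beyond the scatter is therefore expected in this assay, and no direction can be argued. The expected change is a 1.2-fold lower number from compound 2 to compound 3 (0.06 log units; within the scatter) on this estimate. For compound 3 the estimated value is 1700 nM with an expected range from 600 nM to 4200 nM in this read-out.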

Compound 3, maximal plasma concentration: 840 nM
Compound 3: the middle estimate sits 2.0-fold (0.31 log units) above what was measured, and the stated range covers the measured number.
By their numbers in this assay, from the lowest: compound 3; then compounds 2 and 1 (each within the scatter of the next).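

At this amide-type nitrogen the choice of group does move the number in this assay: the earlier exchange of isopropyl for 2-methoxyethyl stayed within the scatter (a 1.1-fold lower number from compound 1 to compound 2 (0.03 log units; within the scatter)), whereas 4-methoxycyclohexyl gives a step beyond it from either earlier group (a 2.3-fold lower number from compound 2 to compound 3 (0.37 log units; beyond the scatter); a 2.5-fold lower number from compound 1 to compound 3 (0.39 log units; beyond the scatter)). Both new steps are modest, and both point the same way, towards less compound in the circulation at the dose given. The methoxy group stands on both sides of the step from the 2-methoxyethyl compound, so what the count adds there is the six-membered non-aromatic ring of carbon only, and compound 3, the only one of the three carrying a ring at this nitrogen, is also the only one set apart from the others. Nothing available gives a reason for this lower number.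

The compounds shown leave open whether the step belongs to the ring itself or to the methoxy group on it, which a plain cyclohexyl or a 4-hydroxycyclohexyl at this nitrogen would help to separate. They also leave open whether the two defined stereocentres matter, a question for the opposite stereoisomer of the 4-methoxycyclohexyl group.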